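The source may hold more compounds than are shown below. What is called first, only, known or untested is meant among the compounds shown, and "the series" means these compounds.

Measured compounds:
compound 1, `Nc1ccc(-c2cnc(C(=O)CCCCCCc3ccccc3)o2)cc1`, in an assay (Rattus norvegicus) for inhibition of Fatty-acid amide hydrolase 1 (Homo sapiens) (a higher number here means a weaker inhibitor, a lower number a stronger inhibitor), compound 1 gives 90 nM
compound 2, `COc1ncc(-c2cnc(C(=O)CCCCCCc3ccccc3)o2)c(OC)n1`, in this assay compound 2 gives 26 nM

Of these two numbers, compound 1 has the higher one; its nearest neighbour, compound 2, gives a lower number, and that gap is beyond the scatter of the assay. Compound 3, `CN(C)C(=O)c1cnc(C(=O)CCCCCCc2ccccc2)o1`, has not been measured. It differs from compound 1 in one place: dimethylcarbamoyl in place of 4-aminophenyl on an aromatic carbon. For the measured compounds named here, no step between two measured compounds carries this change, so there is no direct precedent among the numbers in hand. Within the shared core, both measured compounds carry a six-membered aromatic ring at the place where compound 3 carries dimethylcarbamoyl, which gives no guide for the new group. A step toward a weaker inhibitor is expected, a 5.6-fold higher number from compound 1 to compound 3 (0.74 log units; beyond the scatter), beyond the scatter. For compound 3 in this assay an inhibition constant of about 500 nM is estimated, within a range from 100 nM to 3000 nM.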

Compound 3, inhibition constant: 2 nM
Compound 3: middle estimate off by 250-fold (2.40 log units), on the high side, outside the stated range (below it).
By their numbers in this assay, from the lowest: compound 3; then compound 2; then compound 1.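

In this assay, dimethylcarbamoyl in place of 4-aminophenyl on this aromatic carbon gives a 45-fold lower number from compound 1 to compound 3 (1.65 log units; beyond the scatter) and is a large step toward a stronger inhibitor. The two earlier compounds both carried a six-membered aromatic ring here, so they could not show that this position needs no ring at all: a smaller group with no ring and no hydrogen-bond donor is accepted at this carbon, and with a far lower number. Nothing measured here accounts for the size of this step.

Going by these compounds, it remains open whether the two methyl groups are needed or whether the carbonyl alone suffices, which a primary amide, a methyl ester or a carboxylic acid at this carbon could test. Also open, on these data alone, is whether a cyclic amide such as a pyrrolidine amide, or a shorter chain in place of the phenylhexyl chain, would keep this strength of inhibition.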